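Changing the Group on the Aromatic Nitrogen After Two Limits

The source may hold more compounds than are shown below. What is called first, only, known or untested is meant among the compounds shown, and "the series" means these compounds.

In a functional assay on HeLa cells (Homo sapiens) for antiproliferative activity, read by MTT assay, with a stated time of 72 h (on this read-out higher numbers stand for weaker inhibition of growth and lower numbers for stronger inhibition of growth), compound 1 (`Cc1c(C(=O)Nc2ccc(SC#N)cc2)nnn1-c1ccc(C(C)C)cc1`) shows only a limit (> 100000 nM) and no number. Compound 2 (`Cc1ccc(-n2nnc(C(=O)Nc3ccc(SC#N)cc3)c2C)cc1C`) likewise shows only a limit (> 100000 nM) in this assay and no number. Compound 3 (`Cc1ccc(Cl)cc1-n1nnc(C(=O)Nc2ccc(SC#N)cc2)c1C`) carries 5-chloro-2-methylphenyl in place of 3,4-dimethylphenyl on an aromatic nitrogen. Going by the values given here, only one measured step bears on this (a step that the two limits leave unreadable from compound 1 to compound 2), and it offers no size to carry over. Weak growth inhibition is expected to persist, with an estimated step (an at least 1.2-fold lower number from compound 2 to compound 3 (0.09 log units; that floor lies within the scatter)) in this assay of no firm direction. For compound 3 the estimated value is 80000 nM in a range from 20000 nM to 100000 nM and may again prove only a limit.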

Compound 3, concentration for 50% growth inhibition: 91300 nM
Beside the measured number, compound 3's estimate is 1.1-fold (0.06 log units) below it, and the stated range covers the measured number.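

Compound 3 is the only one of the three to give an actual number in this assay, so a readable value can be reached with a change at this position. The change amounts to no more than an at least 1.0-fold lower number from compound 2 to compound 3 (0.03 log units; that floor lies within the scatter), and likewise an at least 1.0-fold lower number from compound 1 to compound 3 (0.03 log units; that floor lies within the scatter), so no gain in growth inhibition can be claimed. Compound 1 and compound 2 give limits, not numbers: the limit of > 100000 nM in this assay, at which 2 of the 3 values shown sit.

On these data alone, whether an amine or a carboxylic acid on the phenyl ring would give a clearly lower number remains open. So does whether the chlorine or the methyl group of 5-chloro-2-methylphenyl accounts for the number given by compound 3.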